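The compounds below may be only part of what the source reports. "The series", "measured", "known", "first", "only" and "open" are said of these compounds alone.

Of the compounds shown here, three built on one shared core have been measured in a functional assay on the whole organism (Tail, strain ICR) with Mus musculus as the target, in the tail flick test, with a stated time of 60 min, at a dose of 25 umol/kg by the oral route; on this read-out lower numbers stand for a weaker effect and higher numbers for a stronger effect at the one dose given. Compound 1 `CSCC[C@H](NC(=O)CN(c1nc(Cl)nc2[nH]cnc12)C1CC1)C(=O)OCc1ccccc1` gives 30.8%, compound 3 `NC(=O)CC[C@H](NC(=O)CN(c1nc(Cl)nc2[nH]cnc12)C1CC1)C(=O)OCc1ccccc1` gives 33.1%, and compound 2 `CSCC[C@H](NC(=O)CN(c1nc(Cl)nc2[nH]cnc12)C1CC1)C(=O)O` gives 22.8%. Compound 2 stands at the low end of these numbers, within the scatter of compound 1 but beyond the scatter of compound 3. Compound 4 `O=C(O)CNC(=O)CN(c1nc(Cl)nc2[nH]cnc12)C1CC1` has not yet been measured; it differs from compound 2 by hydrogen in place of 2-(methylsulfanyl)ethyl on a saturated chain carbon bound to an amide-type nitrogen and a carbonyl carbon. For the measured compounds named here, no measured step removes this chain outright. The closest guidance is a number 2.3 percentage points higher from compound 1 to compound 3 (within the scatter), a change on the same chain, and a number 8 percentage points lower from compound 1 to compound 2 (within the scatter), both within the scatter. No step beyond the scatter is therefore expected, and compound 4 is estimated at 21%, between 8% and 36%, which would correspond to a number 1.8 percentage points lower from compound 2 to compound 4 (within the scatter).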

Compound 4, a percentage reported as activity, at one dose (the size of the read-out at that dose, not a potency): 38.9%
The estimate for compound 4 lay 17.9 percentage points below the measured number; the measured number lies above the stated range.
By their numbers in this assay, from the lowest: compounds 2, 1, 3 and 4 (each within the scatter of the next, the first and the last beyond it).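

In this assay, the step from the 2-(methylsulfanyl)ethyl chain to plain hydrogen gives a number 16.1 percentage points higher from compound 2 to compound 4 (beyond the scatter), the only step shown so far that goes beyond the scatter. At this saturated chain carbon, then, the effect at this dose does not depend on having a side chain, and in this pair it is larger without one. Nothing shown offers a reason for this rise.

A single methyl group at this carbon could show whether any side chain lowers the number. A benzyl ester on compound 4 could show whether the hydrogen at this position gives a similar rise with that ester in place.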